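Furan to thiophene swap on a second core

This account rests on a few compounds, and the source may have more. Where it says the series, first, only, none or still open, it means among the compounds named here.

Compound 1 `CC1=NN(C2=NC(C)=C(C(=O)Nc3cccc([N+](=O)[O-])c3)C(c3ccc(O)cc3O)N2)C(=O)/C1=C/c1ccco1` and compound 2 `CC1=NN(C2=NC(C)=C(C(=O)Nc3cccc([N+](=O)[O-])c3)C(c3ccc(O)cc3O)N2)C(=O)/C1=C/c1cccs1` share one core, while compound 3 `CC1=C(C(=O)Nc2cccc([N+](=O)[O-])c2)C(c2ccc(O)cc2O)NC(NN2C(=O)/C(=C\c3ccco3)SC2=S)=N1` and compound 4 `CC1=C(C(=O)Nc2cccc([N+](=O)[O-])c2)C(c2ccc(O)cc2O)NC(NN2C(=O)/C(=C\c3cccs3)SC2=S)=N1` share another; the difference between the two cores is not broken down here. In a functional assay on A-431 cells (Homo sapiens) for inhibition, read by sulforhodamine B assay, with a stated time of 2 days (on this read-out higher numbers stand for weaker inhibition of growth and lower numbers for stronger inhibition of growth), compound 1 gives 15800 nM, compound 2 gives 37100 nM, and compound 3 gives 28900 nM. The change from compound 1 to compound 2 is thiophen-2-yl in place of furan-2-yl on a double-bonded chain carbon bound to a double-bonded ring carbon, and it made a 2.3-fold higher number from compound 1 to compound 2 (0.37 log units; beyond the scatter). The change from compound 3 to compound 4 is thiophen-2-yl in place of furan-2-yl on a double-bonded chain carbon bound to a double-bonded ring carbon, the same change on the other core. Compound 4 is unmeasured. Among the compounds with values here, the only guide is the single measured pair, and one step on a different core is a thin basis, so the expectation carries real uncertainty. Because compound 1 to compound 2 gave a 2.3-fold higher number from compound 1 to compound 2 (0.37 log units; beyond the scatter), compound 3 to compound 4 is expected to give a 2.0-fold higher number from compound 3 to compound 4 (0.30 log units; within the scatter) in this assay. The estimate for compound 4 in this assay is 58000 nM, with an expected range from 25000 nM to 135000 nM.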

Compound 4, concentration for 50% growth inhibition: 2780 nM
Beside the measured number, compound 4's estimate is 21-fold (1.32 log units) above it; measured number below the stated range.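

In this assay, thiophen-2-yl in place of furan-2-yl on the second core gave a 10-fold lower number from compound 3 to compound 4 (1.02 log units; beyond the scatter), a large gain in growth inhibition. The same change therefore did not carry from one core to the other, either in size or in direction, and the two steps point opposite ways: the same change on two cores in this assay, a 2.3-fold higher number (0.37 log units; beyond the scatter) from compound 1 to compound 2 and a 10-fold lower number (1.02 log units; beyond the scatter) from compound 3 to compound 4, 24-fold (1.39 log units) apart, beyond the scatter of two such steps. This shows that, among these four compounds, the outcome of the swap depended on the core that carried it, but with only one pair on each core it does not show which part of the cores is responsible or why the direction reversed.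

The compounds shown leave open whether a similar reversal would appear with another group at this place, such as phenyl or pyridin-2-yl. They also leave open whether the thiophen-2-yl gain on the second core would hold if the nitro group gave way to an amine.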